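Trading a tert-leucine for a valine side chain

This account rests on a few compounds, and the source may have more. Where it says the series, first, only, none or still open, it means among the compounds named here.

Measured compounds:
Compound 1 `CC(C)(C)[C@@H](N)C(=O)NCc1ccc(COc2cccc(F)c2)cc1`: 30 mg/kg
Compound 2 `CC(C)(C)[C@@H](N)C(=O)NCc1ccccc1`: 11 mg/kg

Compound 1 carries the same amino-acid amide as compound 2 but adds a fluorophenoxymethyl arm on the benzyl group. In a functional assay on the whole organism (strain albino Sprague-Dawley) with Rattus norvegicus as the target, in the maximal electroshock model (a lower number here means that less compound is needed, a higher number that more compound is needed for the effect), compound 1 gives 30 mg/kg, the highest of the two numbers; compound 2 gives 11 mg/kg, a gap that lies beyond the usual scatter, so the added arm costs potency here.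

Compound 3 `CC(C)[C@H](N)C(=O)NCc1ccc(COc2cccc(F)c2)cc1` keeps that arm and alters only the amino-acid part: 1-amino-2-methylpropyl in place of 1-amino-2,2-dimethylpropyl on a carbonyl carbon. One of the three methyl groups on the branched carbon is removed, leaving a smaller side chain. Going by the values given here, no measured pair in this set shows that change, so its effect must be guessed. A step of moderate size toward a higher number is expected, a 1.7-fold higher number from compound 1 to compound 3 (0.22 log units; within the scatter), although it may fall within the scatter. Compound 3 is estimated at 50 mg/kg, with a range from 20 mg/kg to 130 mg/kg.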

Compound 3, dose for half-maximal effect: > 30 mg/kg
Compound 3: no number, only a limit; the forecaster's own chance of this, stated with the estimate: 10%; the middle value lies beyond the limit too.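

Compound 3 yields only a limit in this assay, > 30 mg/kg, and no exact number. Replacing 1-amino-2,2-dimethylpropyl with 1-amino-2-methylpropyl on the carbonyl carbon therefore gives a number no lower from compound 1 to compound 3 (the limit leaves the size open), so this smaller side chain, with the fluorophenoxymethyl arm kept in place, brings no measurable gain in potency, although the true size of the step cannot be read. The whole comparison rests on one limit: the limit of > 30 mg/kg in this assay, at which 1 of the 3 values shown sits.

The compounds shown leave open how far compound 3 lies past its limit, and so whether this change matters at all or costs a great deal. They also leave open whether a 1-aminoethyl group or a 1-amino-2-methoxyethyl group on the same carbonyl carbon would give a lower number.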